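Removing a methoxy group from acetylated dihydrooxadiazole cores

A few compounds are considered here, and "the series" means these few. Any claim that something is new, unique, unknown or untested is made for them only; others in the source may bear on it.

Four compounds share a common scaffold. Compound 1 `COc1cc(C2=NN(C(C)=O)C(c3cc(OC)c(OC)c(OC)c3)O2)cc(OC)c1OC` and compound 2 `COc1cc(OC)cc(C2OC(c3cc(OC)c(OC)c(OC)c3)=NN2C(C)=O)c1` differ in one place, as do compound 3 `COc1ccc(C2=NN(C(C)=O)C(c3ccccc3OC)O2)cc1` and the unmeasured compound 4 `COc1ccc(C2=NN(C(C)=O)C(c3ccccc3)O2)cc1`. The difference between the core of compound 1 and the core of compound 3 is not broken down here. All are compared in a functional assay on L1210 cells (Mus musculus) for antiproliferative activity, read by MTT assay, with a stated time of 72 h; a higher number here means a weaker inhibitor, a lower number a stronger inhibitor.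

In this assay compound 1 reaches only the limit > 100000 nM, which is a limit of the assay and not a number, as shown by the limit of > 100000 nM in this assay, at which 1 of the 3 values shown sits. Compound 2 gives 5900 nM, and compound 3 gives 5800 nM. The change from compound 1 to compound 2 is hydrogen in place of methoxy on an aromatic carbon, where the site is ortho to two methoxy groups and para to a large group; it produced an at least 16-fold lower number from compound 1 to compound 2 (1.22 log units; beyond the scatter).

The change from compound 3 to compound 4 is hydrogen in place of methoxy on an aromatic carbon, the same kind of change, but here the site is ortho to a large group. For the measured compounds named here, with only one measured step of this kind, and that one starting from a limit, the step is expected to be a 1.7-fold higher number from compound 3 to compound 4 (0.24 log units; within the scatter). Compound 4 is therefore estimated at 10000 nM, between 3000 nM and 40000 nM.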

Compound 4, half-maximal inhibitory concentration: > 100000 nM
Compound 4 was reported as a limit (the forecaster's own chance of this, stated with the estimate: 10%); middle value at least 10-fold (1.00 log units) away from the limit.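

On the core of compound 3, hydrogen in place of methoxy gave an at least 17-fold higher number from compound 3 to compound 4 (1.23 log units; beyond the scatter), the opposite direction to the step on the core of compound 1, so in this assay the change does not carry from one core to the other: the same change on two cores in this assay, an at least 16-fold lower number (1.22 log units; beyond the scatter) from compound 1 to compound 2 and an at least 17-fold higher number (1.23 log units; beyond the scatter) from compound 3 to compound 4, at least 290-fold (2.46 log units) apart, beyond the scatter of two such steps. Going by these compounds, compound 1 and compound 4 each sit at a limit of the assay and not a number, so the true size of both steps stays unknown, though their directions are clear: the limit of > 100000 nM in this assay, at which 2 of the 4 values shown sit. The comparison does not show which feature of the cores or of the two sites sets the direction, and two steps make no rule for the series.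

The compounds shown leave open how a hydroxy group, an amine or a longer chain such as ethoxy at the same site would read on either core. They also leave open whether either direction holds on a further core.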